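This account rests on a few compounds, and the source may have more. Where it says the series, first, only, none or still open, it means among the compounds named here.

Compound 2 `Cn1c(-c2ccc(Cl)cc2)c(CCC(=O)N2CCC(O)(Cc3ccccc3)CC2)c2cc(-c3ccco3)ccc21` gives 0.79 nM in an assay on CHO cells for displacement of a labelled ligand from Substance-P receptor (Homo sapiens) (a higher number here means a weaker inhibitor, a lower number a stronger inhibitor), the highest of the two numbers shown; its nearest neighbour, compound 1 `CC(=O)c1ccc2c(c1)c(CCC(=O)N1CCC(O)(Cc3ccccc3)CC1)c(-c1ccc(Cl)cc1)n2C`, gives 0.19 nM, and the step of a 4.2-fold higher number from compound 1 to compound 2 (0.62 log units; beyond the scatter) is a modest rise from one aryl group to another at the same place. Compound 3 `Cn1c(-c2ccc(Cl)cc2)c(CCC(=O)N2CCC(O)(Cc3ccccc3)CC2)c2cc(-c3ccccn3)ccc21` carries pyridin-2-yl in place of furan-2-yl on an aromatic carbon. Going by the values given here, no measured step swaps one aromatic ring for another of this kind, so the estimate leans only on the modest size of a 4.2-fold higher number from compound 1 to compound 2 (0.62 log units; beyond the scatter). Compound 3 is therefore expected to sit close to compound 2, with a 1.3-fold lower number from compound 2 to compound 3 (0.12 log units; within the scatter) not beyond the scatter, estimated at 0.6 nM, range 0.2 nM to 2 nM.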

Compound 3, half-maximal inhibitory concentration: 1.7 nM
Estimate against measurement, compound 3: 2.8-fold (0.45 log units) below; the range from low to high includes it.
By their numbers in this assay, from the lowest: compound 1; then compound 2; then compound 3.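

Within this assay, the exchange of two aromatic rings with one hetero atom at this place is not silent: pyridin-2-yl for furan-2-yl gives a 2.2-fold higher number from compound 2 to compound 3 (0.33 log units; beyond the scatter). Against acetyl, pyridin-2-yl gives an 8.9-fold higher number from compound 1 to compound 3 (0.95 log units; beyond the scatter), so compound 3 has the highest number of the three, with all three steps beyond the scatter. Nothing given here accounts for this order. The compounds shown leave open whether ring size or the hetero atom sets the step, as both change together. Going by these compounds, how phenyl or pyridin-3-yl would fall at this place also remains open.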